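Dropping the Ring Methyl of Compound 1: An Expectation

A few compounds are considered here, and "the series" means these few. Any claim that something is new, unique, unknown or untested is made for them only; others in the source may bear on it.

Compound 1 `CC(=O)O[C@@H]1OC(=O)[C@](C)(C(C)=O)[C@@H]1C` is examined in a functional assay on MCF7 cells (Homo sapiens) for cytotoxicity, read by MTT assay (on this read-out lower numbers stand for stronger inhibition and higher numbers for weaker inhibition), where compound 1 gives 6000 nM. Its closest companion is compound 2 `CC(=O)O[C@@H]1OC(=O)[C@](C)(C(=O)CBr)[C@@H]1C`, which in this assay gives 4000 nM; the step of a 1.5-fold lower number from compound 1 to compound 2 (0.18 log units; within the scatter), a bromo in place of hydrogen on a saturated chain carbon bound to a carbonyl carbon, stays within the scatter, so these two numbers cannot be separated. Compound 3 `CC(=O)O[C@@H]1OC(=O)[C@](C)(C(C)=O)[C@@H]1C(C)C` reaches only the limit of > 50000 nM in this assay, which is a limit rather than a number. That limit, (the limit of > 50000 nM in this assay, at which 1 of the 3 values shown sits), is where the step of an at least 8.3-fold higher number from compound 1 to compound 3 (0.92 log units; beyond the scatter) ends, an isopropyl in place of methyl on a saturated ring carbon.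

Compound 4 `CC(=O)O[C@@H]1OC(=O)[C@@H](C(C)=O)[C@@H]1C` differs from compound 1 by hydrogen in place of methyl on a saturated ring carbon. For the measured compounds named here, no measured step makes this same exchange. The step to compound 3 shows that altering a saturated ring carbon of the shared core can carry the number beyond the scatter, whereas the chain change to compound 2 left it unmoved. The expected step of a 1.7-fold higher number from compound 1 to compound 4 (0.22 log units; within the scatter) is therefore a modest weakening, smaller than the loss recorded as an at least 8.3-fold higher number from compound 1 to compound 3 (0.92 log units; beyond the scatter). Compound 4 is estimated at 10000 nM in this assay, with a range from 3000 nM to 40000 nM.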

Compound 4, half-maximal inhibitory concentration: > 50000 nM
Compound 4 ended at the assay's limit; the forecaster's own chance of this, stated with the estimate: 15%; at least 5.0-fold (0.69 log units) between middle value and limit.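

In this assay the step of an at least 8.3-fold higher number from compound 1 to compound 4 (0.92 log units; beyond the scatter) ends at a limit of the assay and not at a number, yet it shows that removing a single methyl, one heavy atom, is enough to leave the scatter behind. Until now only isopropyl in place of methyl on the ring atom that bears a methyl group had done this, so the shared core proves sensitive at a second saturated ring carbon, and to the removal of a group as well as to the enlargement of one. Both changes to compound 1 end in the same place, so neither step has a full size and the two cannot be ranked: the limit of > 50000 nM in this assay, at which 2 of the 4 values shown sit.

Compound 1 gives 6000 nM, and the compounds shown leave open whether any other group on this ring carbon, such as an ethyl or a hydroxymethyl, would keep the number near that value. They also leave open whether the bromo of compound 2 would change anything once the methyl is gone, and how far beyond the limit compound 4 really lies.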